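Methoxy for Methyl on the Outer Phenoxy Ring

A few compounds are considered here, and "the series" means these few. Any claim that something is new, unique, unknown or untested is made for them only; others in the source may bear on it.

In a functional assay on MIA PaCa-2 cells (Homo sapiens) for antiproliferative activity, read by MTT assay, with a stated time of 72 h (on this read-out higher numbers stand for an effect only at larger amounts of compound and lower numbers for an effect already at smaller amounts), compound 2 `CNC(=O)c1cccc(Cn2nc(C)c(NC(=O)c3ccc(COc4cccc(C)c4)cc3)c2C)c1` gives 6200 nM, level with compound 1 `CNC(=O)c1cccc(Cn2nc(C)c(NC(=O)c3ccc(COc4ccccc4)cc3)c2C)c1`, which gives 6200 nM in this assay. Going by the values given here, the only measured step, no change at the digits printed from compound 1 to compound 2 (within the scatter), came with methyl in place of hydrogen on an aromatic carbon and moved nothing beyond the scatter.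

Compound 3 `CNC(=O)c1cccc(Cn2nc(C)c(NC(=O)c3ccc(COc4ccccc4OC)cc3)c2C)c1` differs from compound 2 by 2-methoxyphenyl in place of 3-methylphenyl on an oxygen on a saturated carbon. This change is somewhat larger than the one already measured, yet the record holds nothing that points to a direction, so the expected step is no change at the digits printed from compound 2 to compound 3 (within the scatter), none beyond the scatter. Compound 3 is therefore estimated at 6200 nM in this assay, with a likely range from 3000 nM to 13000 nM.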

Compound 3, half-maximal effective concentration: 8500 nM
The estimate for compound 3 lay 1.4-fold (0.14 log units) below the measured number; low and high end bracket the measured number.
By their numbers in this assay, from the lowest: compounds 1, 2 and 3 (each within the scatter of the next).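

In this assay the outer phenoxy ring now carries an oxygen-bearing group: 2-methoxyphenyl in place of 3-methylphenyl gave a 1.4-fold higher number from compound 2 to compound 3 (0.14 log units; within the scatter), and methoxy in place of hydrogen gave a 1.4-fold higher number from compound 1 to compound 3 (0.14 log units; within the scatter). Neither the added oxygen nor the different placing of the substituent on this ring moved the number beyond the scatter. No measurement at hand bears on this result. The compounds shown leave open whether an amine or a carboxylic acid on this ring would move the number beyond the scatter, and whether 3-methoxyphenyl would read the same as 2-methoxyphenyl.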